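Swapping chloro for trifluoromethyl on compound 3

A few compounds are considered here, and "the series" means these few. Any claim that something is new, unique, unknown or untested is made for them only; others in the source may bear on it.

In an in vitro ADME assay on microsomes from liver (Homo sapiens) for metabolic stability (a lower number here means slower removal, a higher number faster removal of the compound), compound 3 (`CCc1nc2nc(C)cc(Nc3ccc(Cl)cc3)n2n1`) gives 12.8 mL.min-1.g-1. Compound 2 (`CCOc1nc2nc(C)cc(Nc3ccc(C(F)(F)F)cc3)n2n1`) gives 7 mL.min-1.g-1, and these two numbers lie within the usual scatter of each other. Compound 1 (`Cc1cc(Nc2ccc(C(F)(F)F)cc2)n2nc(CCO)nc2n1`) reports only a limit, < 5 mL.min-1.g-1, and not a number.

Compound 4 (`CCc1nc2nc(C)cc(Nc3ccc(C(F)(F)F)cc3)n2n1`) matches compound 3 except for one group on an aromatic carbon of a six-membered aromatic ring of carbon only, para to a large group: trifluoromethyl in place of chloro (trifluoromethyl in place of chloro on an aromatic carbon). Going by the values given here, no measured step makes this swap. Among the compounds with values here, the one measured step, an at least 1.4-fold higher number from compound 1 to compound 2 (0.14 log units; that floor lies within the scatter), is a different change, ethoxy in place of 2-hydroxyethyl, and its size is only a floor. The nearest indirect evidence is compound 2, which carries trifluoromethyl together with ethoxy and gives 7 mL.min-1.g-1, within the scatter of the value for compound 3. No change beyond the scatter is therefore expected in this assay. The expected step is a 1.3-fold lower number from compound 3 to compound 4 (0.11 log units; within the scatter). Compound 4 is estimated at 10 mL.min-1.g-1, with an expected range from 5 mL.min-1.g-1 to 20 mL.min-1.g-1.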

Compound 4, intrinsic clearance in microsomes: < 5 mL.min-1.g-1
Compound 4: no number, only a limit (the forecaster's own chance of this, stated with the estimate: 10%); middle value at least 2.0-fold (0.30 log units) away from the limit.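

In this assay, going by these compounds alone, the chloro group of compound 3 gives way to trifluoromethyl on the aromatic carbon para to a large group, and this single swap produces an at least 2.5-fold lower number from compound 3 to compound 4 (0.40 log units; beyond the scatter), a change beyond the scatter that no earlier pair could show. With trifluoromethyl held fixed, ethyl in place of ethoxy gives an at least 1.4-fold lower number from compound 2 to compound 4 (0.14 log units; that floor lies within the scatter), so that second change is not shown to matter on these data. Compound 4 reports a limit and not a number, which leaves both steps as floors: the limit of < 5 mL.min-1.g-1 in this assay, at which 2 of the 4 values shown sit.

The step between compound 1 and compound 4 cannot be read, since both report limits. Going by these compounds, whether a different group at this same place, such as a bromo, methyl or nitrile group, would give a similar step stays open.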